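The source may report more compounds than this note shows. Statements on the series, on what has been measured and on what is new or still open speak of the compounds shown alone.

Compound 1 `NC1=NC2(CCOCC2)N(OCCCOc2ccccc2)C(N)=N1`: in an assay on isolated protein for inhibition of Dihydrofolate reductase (Homo sapiens), read by spectrophotometry, using NADPH, with stated times of 5 s and 6 min, tested at 5 uM (a lower number here means a weaker effect, a higher number a stronger effect of the compound at the concentration tested), compound 1 gives > 90%, which is a limit of the assay rather than a number.
Compound 2 `NC1=NC2(CCOCC2)N(OCCCOc2cccc(Cl)c2)C(N)=N1`: in this assay compound 2 gives 83.2%.

Among the compounds with values here, compound 2 therefore carries the only value that is a plain number; the other value, that of compound 1, sits at a limit of the assay (the limit of > 90% in this assay, at which 1 of the 2 values shown sits). Within the data shown here, the single measured step, a number at least 6.8 percentage points lower from compound 1 to compound 2 (that floor lies within the scatter), came with chloro in place of hydrogen on an aromatic carbon, and its floor lies within the usual scatter.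

Compound 3 `NC1=NC2(CCOCC2)N(OCCCOc2ccc(Br)cc2)C(N)=N1` differs from compound 2 by 4-bromophenyl in place of 3-chlorophenyl on an oxygen on a saturated carbon. Among the measured compounds shown here, no measured step exchanges one halogen for another or moves a halogen to a different carbon of that ring, so the step from compound 1 to compound 2 bears on this change only loosely, by showing that a halogen on the ring need not change the read-out much. On that basis no step beyond the scatter is expected in this assay in either direction.

Compound 3 is thus expected to give about 84% in this assay, within a range from 70% to 95%. The expected step of a number 0.8 percentage points higher from compound 2 to compound 3 (within the scatter) is estimated to lie within the scatter.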

Compound 3, a percentage reported as inhibition, at one concentration (the size of the read-out at that concentration, not a potency): > 90%
Compound 3 gave a limit, no number; the forecaster's own chance of this, stated with the estimate: 25%; middle value at least 6 percentage points from the limit.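

Replacing 3-chlorophenyl with 4-bromophenyl on an oxygen on a saturated carbon gives a number at least 6.8 percentage points higher from compound 2 to compound 3 (that floor lies within the scatter), so this exchange is not shown to change the read-out in this assay. In this assay, going by these compounds, compound 3 gives > 90%, which is a limit of the assay and not a number, so a halogen on this ring can go with a read-out at that limit, and the true size of the step stays unknown. The step from compound 1 to compound 3 cannot be read, and the upper end of the read-out can no longer separate these two compounds, as both stand at the same limit: the limit of > 90% in this assay, at which 2 of the 3 values shown sit.

The exchange alters both the halogen and the carbon that carries it, so the compounds shown leave open whether either change alone would matter, and 3-bromophenyl or 4-chlorophenyl would be needed to separate the two. Also open, on these data alone, is how the read-out responds to an amine or a carboxylic acid on this ring, or to a longer chain in place of the present one.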